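The source may hold more compounds than are shown below. What is called first, only, known or untested is meant among the compounds shown, and "the series" means these compounds.

Compound 1 `N[C@H](C(=O)OCCCOC1(c2ccc(Cl)cc2)c2ccccc2C(=O)N1Cc1ccc(Cl)cc1)c1ccccc1` carries the shared core with a three-carbon chain ending in the (amino(phenyl)methyl)carbonyl ester. Among the measured compounds shown here, in a functional assay on HCT-116 cells (Homo sapiens) for inhibition, read by fluorescence, with a stated time of 48 h (a lower number here means a stronger inhibitor of growth, a higher number a weaker inhibitor of growth), compound 1 gives 12000 nM, the lowest of the two numbers so far. For the measured compounds named here, compound 2 `CC(C)(CO)COC1(c2ccc(Cl)cc2)c2ccccc2C(=O)N1Cc1ccccc1` differs from it at several places at once, so no single step connects them; in this assay compound 2 gives 71000 nM, which lies beyond the scatter above compound 1. Compound 3 `O=C1c2ccccc2C(OCCCO)(c2ccc(Cl)cc2)N1Cc1ccc(Cl)cc1` is the free alcohol of the chain: hydrogen in place of (amino(phenyl)methyl)carbonyl on an oxygen on a saturated carbon. Going by the values given here, no measured pair isolates this change. Among the compounds with values here, the only other compound with a free hydroxy on the chain, compound 2, sits high, though it differs elsewhere too, so the comparison is loose. The step of a 3.3-fold higher number from compound 1 to compound 3 (0.52 log units; beyond the scatter) is expected to run upward, a weakening beyond the scatter. Compound 3 is therefore expected at 40000 nM, within a range from 15000 nM to 100000 nM.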

Compound 3, concentration for 50% growth inhibition: 60000 nM
Compound 3: the middle estimate sits 1.5-fold (0.18 log units) below what was measured; the measured number falls inside the stated range.
By their numbers in this assay, from the lowest: compound 1; then compounds 3 and 2 (each within the scatter of the next).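

In this assay, hydrogen in place of (amino(phenyl)methyl)carbonyl on an oxygen on a saturated carbon gives a 5.0-fold higher number from compound 1 to compound 3 (0.70 log units; beyond the scatter). Among the compounds shown here, this is the first single-place step, and it shows that growth inhibition at this end of the chain weakens beyond the scatter when the ester gives way to the free alcohol, though the step is modest. No measurement available here speaks to the origin of this step.

The step takes away the amino group, the phenyl ring and the carbonyl together, leaving open which of them carries the difference. As far as these compounds go, how an acetyl ester, an amine at the chain end or a longer chain would read in this assay also remains open.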